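The source may report more compounds than this note shows. Statements on the series, on what has been measured and on what is new or still open speak of the compounds shown alone.

Compound 2 `Cc1cc(C)cc(-n2nncc2CN2C(=O)C3(C(C#N)=C(N)Oc4c(N)cc5nc6ccccc6nc5c43)c3ccccc32)c1` carries a 3,5-dimethylphenyl on an aromatic nitrogen, and in a functional assay on A549 cells (Homo sapiens) for antiproliferative activity, read by MTT assay, with a stated time of 48 h (a higher number here means a weaker inhibitor, a lower number a stronger inhibitor), compound 2 gives 31200 nM. Among the measured compounds shown here, its only comparator is compound 1 `N#CC1=C(N)Oc2c(N)cc3nc4ccccc4nc3c2C12C(=O)N(Cc1cnnn1-c1ccccc1Br)c1ccccc12`, which bears a 2-bromophenyl on that aromatic nitrogen; in this assay compound 1 gives 27400 nM, and the two numbers sit within the scatter of each other. Compound 3 `N#CC1=C(N)Oc2c(N)cc3nc4ccccc4nc3c2C12C(=O)N(Cc1cnnn1-c1c(F)cccc1F)c1ccccc12` differs from compound 2 by 2,6-difluorophenyl in place of 3,5-dimethylphenyl on an aromatic nitrogen. For the measured compounds named here, the one measured step that bears on this change is the exchange of the aryl group on the same aromatic nitrogen, a 1.1-fold higher number from compound 1 to compound 2 (0.06 log units; within the scatter), which left the number essentially unchanged. With no step beyond the scatter recorded for this position, no shift beyond the scatter is expected for compound 3 in this assay, which amounts to an estimated 1.1-fold lower number from compound 2 to compound 3 (0.03 log units; within the scatter). Compound 3 is therefore estimated at 29000 nM, with an expected range from 13000 nM to 65000 nM.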

Compound 3, half-maximal inhibitory concentration: > 50000 nM
Compound 3 gave a limit, no number; the forecaster's own chance of this, stated with the estimate: 10%; middle value at least 1.7-fold (0.23 log units) from the limit.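

In this assay compound 3 gives only a limit of the assay, not a number, and it is the only one of the three aryl groups shown on this aromatic nitrogen to do so: the limit of > 50000 nM in this assay, at which 1 of the 3 values shown sits. Set against the two measured numbers, this gives only floors, an at least 1.6-fold higher number from compound 2 to compound 3 (0.20 log units; that floor lies within the scatter) and an at least 1.8-fold higher number from compound 1 to compound 3 (0.26 log units; that floor lies within the scatter), so neither step is shown to go beyond the scatter, and the true size of either remains unknown. The flat reading of this position from compound 1 and compound 2 is therefore neither confirmed nor overturned by 2,6-difluorophenyl.

Still open, as far as these compounds go, is where compound 3 lies beyond its limit. Also open, from the compounds shown here alone, is how an aminophenyl group, a pyridyl ring or a longer alkyl chain on this aromatic nitrogen would read in this assay.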